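The source may report more compounds than this note shows. Statements on the series, on what has been measured and on what is new or still open speak of the compounds shown alone.

Of the compounds shown here, three have so far been measured in a functional assay on cells for positive allosteric modulation of metabotropic glutamate receptor 5 (Rattus norvegicus), read by calcium flux; on this read-out lower numbers stand for an effect already at smaller amounts and higher numbers for an effect only at larger amounts of compound. Compound 1, `Cc1ccc(C(=O)Nc2cc(-c3ccccc3)nn2-c2ccccc2)cc1`, gives 64 nM in this assay. Compound 3, `N#Cc1cccc(C(=O)Nc2cc(-c3ccccc3)nn2-c2ccccc2Br)c1`, gives 50 nM, and compound 2, `N#Cc1cccc(-n2nc(-c3ccccc3)cc2NC(=O)c2ccccc2)c1`, gives 117 nM. Among these three numbers compound 1 lies nearest to compound 3 and furthest from compound 2, yet all three sit within the usual scatter of repeated measurements, so on these data none of them can be set apart from the others.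

Compound 4, `Cc1ccc(C(=O)Nc2cc(-c3ccccc3)nn2-c2ccccc2)cn1`, has not yet been measured. It differs from compound 1 in a single place: 6-methylpyridin-3-yl in place of 4-methylphenyl on a carbonyl carbon. Everything else, the shared core of compound 1 with its two phenyl rings and the amide linking it to the carbonyl, is kept; only the ring that sits on the carbonyl carbon is exchanged.

No measured pair among compounds 1, 2 and 3 shows this sort of exchange, so there is no observed step to lean on, and the data give no reason to expect a move beyond the scatter in either direction. Compound 4 is therefore estimated at 90 nM, with a range from 30 nM to 270 nM. The step of a 1.4-fold higher number from compound 1 to compound 4 (0.15 log units; within the scatter) is expected to be small and to stay within the scatter.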

Compound 4, half-maximal effective concentration: 280 nM
Compound 4: middle estimate off by 3.1-fold (0.49 log units), on the low side, and the stated range ends below it.
By their numbers in this assay, from the lowest: compounds 3, 1 and 2 (each within the scatter of the next, the first and the last beyond it); then compound 4.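

In this assay, 6-methylpyridin-3-yl in place of 4-methylphenyl on a carbonyl carbon gives a 4.4-fold higher number from compound 1 to compound 4 (0.64 log units; beyond the scatter), a step that lies beyond the usual scatter. Among these compounds, no two of the earlier compounds differed in only one place, so this pair gives the first direct reading of a single change, and it shows that the read-out responds to what sits on this carbonyl carbon: the number of heavy atoms stays the same, one ring carbon becomes a nitrogen and a hydrogen-bond acceptor is added, yet the number rises clearly. Nothing measured here explains the rise, so the step can be stated only as an observation.

From the compounds shown here alone, this is a single pair, so it remains open whether the ring nitrogen itself matters or whether any other exchange on this carbonyl carbon would shift the number in the same way. Also open, going by these compounds, are how groups such as 4-chlorophenyl, 4-methoxyphenyl or a saturated cyclohexyl ring would behave at this place, and whether the same exchange would give a step of similar size on the core of compound 3.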